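Chain extension in the gem-dimethyl acid series

A few compounds are considered here, and "the series" means these few. Any claim that something is new, unique, unknown or untested is made for them only; others in the source may bear on it.

Compound 2 `CC(C)(CCC/C=C(/c1ccccc1)c1cccnc1)C(=O)O` gives the lower of the two numbers in an assay (Equus caballus) for inhibition of Thromboxane-A synthase (Homo sapiens), using microsomes (on this read-out lower numbers stand for stronger inhibition and higher numbers for weaker inhibition), at 30 nM. Compound 1 `O=C(O)CCC/C=C(/c1ccccc1)c1cccnc1` gives 280 nM, and a 9.3-fold lower number from compound 1 to compound 2 (0.97 log units; beyond the scatter). Compound 3 `CC(C)(CCCC/C=C(/c1ccccc1)c1cccnc1)C(=O)O` carries 2-carboxy-2-methylpropyl in place of 1-carboxy-1-methylethyl on a saturated chain carbon, three bonds along the chain from a double-bonded chain carbon. For the measured compounds named here, no measured step changes the length of the chain; the single step known, from carboxy to 1-carboxy-1-methylethyl, does not bear on this change. A shift in this assay beyond the scatter is therefore not expected for compound 3 in either direction. Compound 3 is estimated at 40 nM, with a range of 10 nM to 160 nM. For compound 3 the expected step is a 1.3-fold higher number from compound 2 to compound 3 (0.12 log units; within the scatter).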

Compound 3, half-maximal inhibitory concentration: 38 nM
Compound 3: the middle estimate sits 1.1-fold (0.02 log units) above what was measured; low and high end bracket the measured number.
By their numbers in this assay, from the lowest: compounds 2 and 3 (each within the scatter of the next); then compound 1.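

Replacing 1-carboxy-1-methylethyl with 2-carboxy-2-methylpropyl at this place gives a 1.3-fold higher number from compound 2 to compound 3 (0.10 log units; within the scatter), so in this assay this chain can be longer without leaving the scatter of compound 2. The advantage over compound 1 also remains, at a 7.4-fold lower number from compound 1 to compound 3 (0.87 log units; beyond the scatter). No available evidence accounts for either step.

As far as these compounds go, whether a still longer chain, such as 3-carboxy-3-methylbutyl, stays at this level remains open. So does the outcome of putting a tetrazole or an amide in place of the carboxylic acid on this chain.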